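Moving the chloro to a different carbon of the shared core

The source may hold more compounds than are shown below. What is called first, only, known or untested is meant among the compounds shown, and "the series" means these compounds.

Among the measured compounds shown here, compound 1 `COC(=O)Nc1cc(-c2ccc(OC[C@@](C)(N)CC(C)C)cn2)ccn1` gives 23 nM in an assay on isolated protein for inhibition of AP2-associated protein kinase 1 (Homo sapiens), with a stated time of 3 h, in the presence of a further agent that is not named here (a lower number here means a stronger inhibitor, a higher number a weaker inhibitor), the highest of the two numbers measured so far. For the measured compounds named here, its only measured neighbour, compound 2 `COC(=O)Nc1cc(-c2ccc(OC[C@@](C)(N)CC(C)C)c(Cl)n2)ccn1`, carries a chloro on the same ring and gives 0.5 nM. The step of a 46-fold lower number from compound 1 to compound 2 (1.66 log units; beyond the scatter) was large. Compound 3 `COC(=O)Nc1cc(-c2cc(Cl)c(OC[C@@](C)(N)CC(C)C)cn2)ccn1` differs from compound 1 by chloro in place of hydrogen on an aromatic carbon, a chloro again but at a different carbon of that ring. Going by the values given here, since the sole measured chloro step was large, a smaller but still favourable step is expected for compound 3, namely a 2.9-fold lower number from compound 1 to compound 3 (0.46 log units; beyond the scatter). In this assay compound 3 is estimated at 8 nM, with a range of 2 nM to 40 nM.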

Compound 3, half-maximal inhibitory concentration: 1.1 nM
The estimate for compound 3 lay 7.3-fold (0.86 log units) above the measured number, outside the stated range (below it).
By their numbers in this assay, from the lowest: compound 2; then compound 3; then compound 1.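

In this assay, chloro ortho to the (2-amino-2,4-dimethylpentyl)oxy group and opposite the ring nitrogen gives a 21-fold lower number from compound 1 to compound 3 (1.32 log units; beyond the scatter) and so shows that a large step from this change is not confined to the carbon that carries chloro in compound 2. With this second case, both chloro steps measured from compound 1 are large. No measurement shown here accounts for the step at this position. Going by these compounds, whether this carbon favours chloro alone remains open: fluoro, methyl or a nitrile at the same place could give a step of a quite different size.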